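The source may report more compounds than this note shows. Statements on the series, on what has been measured and on what is new or still open speak of the compounds shown alone.

In a functional assay on SK-MEL-2 cells (Homo sapiens) for inhibition, read by sulforhodamine B assay, with a stated time of 48 h, tested at 10 uM (a lower number here means less inhibition, a higher number more inhibition at the concentration tested (going by the name of the read-out)), compound 1 `COc1ccc(-c2cn3ccnc3c(-c3ccc4ncn(C5CCCCC5)c4c3)n2)cc1` gives 94.3%, while compound 2 `c1cn2cc(-c3ccsc3)nc(-c3ccc4ncn(C5CCCCC5)c4c3)c2n1` gives 3.68%, the lowest of the two numbers recorded. Among the measured compounds shown here, the single measured step, a number 90.6 percentage points lower from compound 1 to compound 2 (beyond the scatter), runs opposite to the change now in view. Compound 3 `Brc1ccc(-c2cn3ccnc3c(-c3ccc4ncn(C5CCCCC5)c4c3)n2)cc1` differs from compound 2 by 4-bromophenyl in place of thiophen-3-yl on an aromatic carbon. That step bears on this one, as a six-membered aromatic ring of carbon only returns at the same place, so a large rise is expected, a number 71.3 percentage points higher from compound 2 to compound 3 (beyond the scatter). Compound 3 is estimated at 75%, with a range from 30% to 98%.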

Compound 3, a percentage reported as inhibition, at one concentration (the size of the read-out at that concentration, not a potency): 24.1%
Compound 3: middle estimate off by 50.9 percentage points, on the high side; the whole stated range lies above it.
By their numbers in this assay, from the lowest: compound 2; then compound 3; then compound 1.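

In this assay a six-membered aromatic ring of carbon only at this position does not by itself restore the read-out: a number 20.4 percentage points higher from compound 2 to compound 3 (beyond the scatter) is a modest step, while a number 70.2 percentage points lower from compound 1 to compound 3 (beyond the scatter) is a large one. With that ring held constant, the substituent it carries matters strongly here, and bromo stands much nearer to the thiophen-3-yl compound than to the methoxy compound.

Open, from the compounds shown here alone, is how an unsubstituted phenyl, or a phenyl bearing an amine or a carboxylic acid, would read at this position. No data at hand explain either step.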